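The compounds below may be only part of what the source reports. "The series", "measured", "known", "first", "only" and "open" are said of these compounds alone.

Compound 2 `O=C(O)CCCSCCN1C(=O)CC[C@@H]1/C=C/[C@@H](O)Cc1cccc(N2Cc3ccccc3C2)c1` gives 28 nM in a functional assay on CHO cells for agonist activity at prostaglandin E2 receptor EP4 subtype (Rattus norvegicus), read by cAMP accumulation and immunoassay, with a stated time of 10 min (on this read-out higher numbers stand for an effect only at larger amounts of compound and lower numbers for an effect already at smaller amounts), the higher of the two numbers recorded so far; its nearest neighbour is compound 1 `Cc1cccc(C[C@H](O)/C=C/[C@H]2CCC(=O)N2CCSCCCC(=O)O)c1`, which in this assay gives 5.7 nM. For the measured compounds named here, the only measured step joining them is a 4.9-fold higher number from compound 1 to compound 2 (0.69 log units; beyond the scatter), where a single carbon on the aromatic carbon was replaced by the larger group. Compound 3 `O=C(O)CCCSCCN1C(=O)CC[C@@H]1/C=C/[C@@H](O)Cc1cccc(-c2ccc3[nH]ccc3c2)c1` differs from compound 2 by a group of 9 heavy atoms (8 carbon, 1 nitrogen; one five-membered aromatic ring with 1 hetero atom, one six-membered aromatic ring of carbon only) in place of a group of 9 heavy atoms (8 carbon, 1 nitrogen; one five-membered non-aromatic ring with 1 hetero atom, one six-membered aromatic ring of carbon only), on an aromatic carbon. That measured step is the one that bears on this change, and it shows that a group of this size at that carbon is tolerated at a modest cost. Since the change from compound 2 to compound 3 keeps the same count of atoms and exchanges one such group for another, no step beyond the scatter is expected in this assay; the step expected is a 1.4-fold lower number from compound 2 to compound 3 (0.15 log units; within the scatter). Compound 3 is therefore estimated to give 20 nM in this assay, within a range of 5 nM to 80 nM.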

Compound 3, half-maximal effective concentration: 85 nM
Estimate against measurement, compound 3: 4.3-fold (0.63 log units) below, and the stated range ends below it.
By their numbers in this assay, from the lowest: compound 1; then compound 2; then compound 3.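

In this assay, groups of equal heavy-atom count at this aromatic carbon are not interchangeable: 1H-indol-5-yl in place of the group with the non-aromatic five-membered ring gives a 3.0-fold higher number from compound 2 to compound 3 (0.48 log units; beyond the scatter) and so size alone does not set the value here. Set against methyl, 1H-indol-5-yl gives a 15-fold higher number from compound 1 to compound 3 (1.17 log units; beyond the scatter) and this step is rated large, where the earlier step from methyl to a group of this size was rated modest. Nothing available explains why the two groups differ.

The compounds shown do not separate the aromatic five-membered ring from the hydrogen-bond donor that enters with it. They also leave open how a single phenyl ring or a methoxy group at this carbon would compare with methyl.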